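Chain extension at the sulfamide arm, compound 1 to compound 4

A few compounds are considered here, and "the series" means these few. Any claim that something is new, unique, unknown or untested is made for them only; others in the source may bear on it.

Compound 1 `Cc1ccc(-c2cc(N3CCC(CNS(N)(=O)=O)CC3)ncn2)cc1` is the reference point of the series. In a functional assay on MCF7 cells (Homo sapiens) for antiproliferative activity, read by sulforhodamine B assay, with a stated time of 48 h (on this read-out higher numbers stand for weaker inhibition of growth and lower numbers for stronger inhibition of growth), compound 1 gives 30600 nM, the lowest of the three numbers recorded so far. Its nearest neighbour is compound 3 `NS(=O)(=O)NCC1CCN(c2cc(-c3ccccc3F)ncn2)CC1` with 48500 nM; the step of a 1.6-fold higher number from compound 1 to compound 3 (0.20 log units; within the scatter) stays within the scatter. The furthest is compound 2 `NS(=O)(=O)NCC1CCN(c2cc(-c3ccccc3Cl)ncn2)CC1` with 62400 nM; the step of a 2.0-fold higher number from compound 1 to compound 2 (0.31 log units; beyond the scatter) is modest but beyond the scatter, and between the two halogen analogues a 1.3-fold lower number from compound 2 to compound 3 (0.11 log units; within the scatter) is again within the scatter.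

Compound 4 `Cc1ccc(-c2cc(N3CCC(CCNS(N)(=O)=O)CC3)ncn2)cc1` keeps the aryl group of compound 1 and changes only the arm: (sulfamoylamino)methyl in place of sulfamoylamino on a saturated chain carbon bound to a saturated ring carbon. None of the three measured steps touches this arm; all of them swap the aryl group, and even the largest of them, a 2.0-fold higher number from compound 1 to compound 2 (0.31 log units; beyond the scatter), is only modest. Going by the values given here, there is thus no measured precedent for lengthening the chain, and the one place where the series has been varied shows little movement. The expectation for compound 4 is therefore a step in this assay of no more than the scatter, with no direction assigned: a 1.1-fold higher number from compound 1 to compound 4 (0.06 log units; within the scatter). Compound 4 is estimated at 35000 nM, with a range from 12000 nM to 100000 nM.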

Compound 4, concentration for 50% growth inhibition: 47500 nM
Compound 4: the middle estimate sits 1.4-fold (0.13 log units) below what was measured, and the stated range covers the measured number.
By their numbers in this assay, from the lowest: compounds 1, 4, 3 and 2 (each within the scatter of the next, the first and the last beyond it).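

Going by these compounds alone, this is the first measured change at the arm rather than at the aryl group: in this assay the step of a 1.6-fold higher number from compound 1 to compound 4 (0.19 log units; within the scatter) stays within the scatter, so on this read-out the extension from (sulfamoylamino)methyl to 2-(sulfamoylamino)ethyl does not separate the two compounds. Within the data shown here, the change adds one carbon and leaves the aryl group, the core and the counts of hydrogen-bond donors and acceptors as they were, so the arm now has one measured step of its own, where the earlier steps spoke only of the aryl group. No measurement at hand bears on why the added carbon leaves the number within the scatter.

A single extension on a single aryl group cannot show whether the same holds with the 2-chlorophenyl or 2-fluorophenyl compounds, and one step gives no trend along the chain. Also open, going by these compounds, is how the number would respond to a longer chain such as 3-(sulfamoylamino)propyl, or to an amine or a carboxylic acid at the end of the arm in place of the sulfamoylamino group.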